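Fused bicyclic acyl sulfonamides: carboxy to sulfo exchange

A few compounds are considered here, and "the series" means these few. Any claim that something is new, unique, unknown or untested is made for them only; others in the source may bear on it.

Measured so far in a functional assay (plasma) with Oryctolagus cuniculus as the target; a higher number here means a weaker inhibitor, a lower number a stronger inhibitor:
- compound 1, `CC(C)c1ccc2c(CNC(=O)CNC(=O)c3ccccc3)cc(C(=O)O)c-2cc1`: compound 1 gives > 1000000 nM, which is a limit of the assay.
- compound 2, `CC(C)c1ccc2c(CCCCS(=O)(=O)Nc3ccc(Cl)cc3)cc(S(=O)(=O)O)c-2cc1`: compound 2 gives > 1000000 nM, again a limit.
- compound 3, `CC(C)c1ccc2c(CCCC(=O)NS(=O)(=O)c3ccc(Cl)cc3)cc(C(=O)O)c-2cc1`: compound 3 gives > 1000000 nM, also a limit.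

Compound 3 therefore stands at the limit of this assay and not at a number, and it shares this standing with the other two measured compounds, since (the limit of > 1000000 nM in this assay, at which 3 of the 3 values shown sit). Going by the values given here, no step between two measured compounds is resolved here; the three values say only that none of the compounds inhibits within the tested range.

Compound 4, `CC(C)c1ccc2c(CCCC(=O)NS(=O)(=O)c3ccc(Cl)cc3)cc(S(=O)(=O)O)c-2cc1`, differs from compound 3 by sulfo in place of carboxy on an aromatic carbon. Compound 2 already carries sulfo on the same core and sits at the limit, so no step beyond the scatter is expected from compound 3 to compound 4 in this assay, and a number no higher from compound 3 to compound 4 (the limit leaves the size open) is the step the estimate implies. Compound 4 is accordingly expected to give 1000000 nM, within 300000 nM to 3000000 nM, most likely again reported only as a limit.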

Compound 4, half-maximal inhibitory concentration: 56000 nM
Estimate against measurement, compound 4: 18-fold (1.25 log units) above; the measured number lies below the stated range.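

In this assay, the aromatic carbon of the five-membered ring proves sensitive to the group it carries: sulfo in place of carboxy gives an at least 17-fold lower number from compound 3 to compound 4 (1.25 log units; beyond the scatter), the only change shown that reaches a measurable number. Sulfo alone is not sufficient: compound 2 also carries sulfo on the shared core, but with a sulfonamide chain in place of the acyl sulfonamide chain, and it gives > 1000000 nM, which is a limit. Compound 4 therefore stands alone with a number in this series: the limit of > 1000000 nM in this assay, at which 3 of the 4 values shown sit.

On these data alone, the true size of the step stays open, since compound 3 has only a limit. Also open, as far as these compounds go, is whether a phosphonic acid or a tetrazole at this position, or a longer chain carrying the acyl sulfonamide, would keep or lower the number.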